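The source may hold more compounds than are shown below. What is called first, only, known or untested is meant among the compounds shown, and "the series" means these compounds.

Compound 1 `CC1(C)CC(NC(=O)NCc2ccccc2)c2cc(Br)ccc2O1` measured at 27000 nM
Compound 2 `CC1(C)CC(NC(=O)NCc2ccccc2)c2cc(Cl)ccc2O1` measured at 66000 nM
Compound 3 `COc1ccccc1NC(=S)NC1CC(C)(C)Oc2ccc(Br)cc21` measured at 22000 nM

All three were read in a functional assay on U-373MG ATCC cells (Homo sapiens) for inhibition, read by MTT assay, with a stated time of 72 h (a lower number here means a stronger inhibitor, a higher number a weaker inhibitor), and the numbers are close together. Compound 1 stands level with compound 3 within the scatter, and the step to the remaining analogue is a 2.4-fold higher number from compound 1 to compound 2 (0.39 log units; beyond the scatter) and is modest.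

The next step leads to compound 4 `CC1(C)CC(NC(=O)Nc2ccc(Cl)cc2)c2cc(Br)ccc2O1` in which 4-chlorophenyl stands in place of benzyl on an amide-type nitrogen 4-chlorophenyl in place of benzyl on an amide-type nitrogen and the rest of compound 1 stays the same. Going by the values given here, no measured step changes this group alone. Among the compounds with values here, the one single-place step, chloro in place of bromo on an aromatic carbon, serves only as a gauge of size. Compound 3 differs from compound 1 in more than one place, so compound 3 at 22000 nM does not isolate this change. The data support no direction, and no step beyond the scatter is expected in this assay here. The estimated change is a 1.2-fold lower number from compound 1 to compound 4 (0.09 log units; within the scatter) and it is expected to remain small. For compound 4 the expected value is 22000 nM with an estimated range from 8000 nM to 60000 nM in this series.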

Compound 4, half-maximal inhibitory concentration: 25000 nM
For compound 4 the middle estimate is 1.1-fold (0.06 log units) below the measured one, and the stated range covers the measured number.
By their numbers in this assay, from the lowest: compounds 3, 4 and 1 (each within the scatter of the next); then compound 2.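

In this assay, going by these compounds alone, 4-chlorophenyl in place of benzyl on the amide-type nitrogen gives a 1.1-fold lower number from compound 1 to compound 4 (0.03 log units; within the scatter) and is the first single-place change read at this group, with no change beyond the scatter. Within the data shown here, for this pair, the group on that nitrogen can pass from benzyl to 4-chlorophenyl without a readable shift, while the only step beyond the scatter so far, a 2.4-fold higher number from compound 1 to compound 2 (0.39 log units; beyond the scatter), lies at the chloro in place of bromo on an aromatic carbon. No measurement offered here accounts for this flat result.

On these data alone, whether the same holds for a different kind of group on that nitrogen, such as a longer alkyl chain or a chain ending in a carboxylic acid, stays open. Also open, as far as these compounds go, is whether 4-chlorophenyl would read the same with chloro in place of bromo on the aromatic carbon.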